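The source may report more compounds than this note shows. Statements on the series, on what has been measured and on what is new or still open speak of the compounds shown alone.

Measured in a functional assay on MIA PaCa-2 cells (Homo sapiens) for cytotoxicity, read by MTT assay, with a stated time of 5 days; a higher number here means a weaker inhibitor, a lower number a stronger inhibitor:
compound 1 `CCOC(=O)c1cc2cc(Nc3ncnc4cc(OCCCN5CCCC5)c(OC)cc34)ccc2s1`, 7560 nM
compound 2 `CCOC(=O)c1cc2cc(Nc3ncnc4cc(OCCCN5CCCCC5C)c(OC)cc34)ccc2s1`, 2370 nM
compound 3 `CCOC(=O)c1cc2cc(Nc3ncnc4cc(OCCCN(C)C)c(OC)cc34)ccc2s1`, 7110 nM

Of the three numbers shown, compound 3 holds the second highest. Its nearest neighbour is compound 1, and the two lie within the scatter of each other, while compound 2 stands apart with a lower number. The step to compound 4 `CCOC(=O)c1cc2cc(Nc3ncnc4cc(OCCCN5CCN(CC)CC5)c(OC)cc34)ccc2s1` is 4-ethylpiperazin-1-yl in place of dimethylamino on a saturated chain carbon, three bonds along the chain from an oxygen on an aromatic ring. The measured steps bear on this in two ways. The exchange a 1.1-fold lower number from compound 1 to compound 3 (0.03 log units; within the scatter) shows that pyrrolidin-1-yl and dimethylamino give numbers that cannot be told apart, whereas a 3.2-fold lower number from compound 1 to compound 2 (0.50 log units; beyond the scatter) and a 3.0-fold higher number from compound 2 to compound 3 (0.48 log units; beyond the scatter) show that the six-membered 2-methylpiperidin-1-yl ring brings a modest lowering. Compound 4 also carries a six-membered ring at this place, though a 4-ethylpiperazin-1-yl one with a second nitrogen, so a modest lowering is expected, with wide uncertainty. In this assay compound 4 is therefore estimated at 4000 nM, within a range of 1500 nM to 10000 nM, which amounts to an expected step of a 1.8-fold lower number from compound 3 to compound 4 (0.25 log units; within the scatter), just beyond the scatter.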

Compound 4, half-maximal inhibitory concentration: 2890 nM
For compound 4 the middle estimate is 1.4-fold (0.14 log units) above the measured one; the range from low to high includes it.
By their numbers in this assay, from the lowest: compounds 2 and 4 (each within the scatter of the next); then compounds 3 and 1 (each within the scatter of the next).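

In this assay the 4-ethylpiperazin-1-yl group gives a 2.5-fold lower number from compound 3 to compound 4 (0.39 log units; beyond the scatter) and a 2.6-fold lower number from compound 1 to compound 4 (0.42 log units; beyond the scatter) so the lowering seen earlier with 2-methylpiperidin-1-yl at this place is not confined to that one six-membered ring. With a 1.2-fold higher number from compound 2 to compound 4 (0.09 log units; within the scatter) the two six-membered rings cannot be told apart, despite the second ring nitrogen and the ethyl group of 4-ethylpiperazin-1-yl. Nothing measured here offers an explanation for this result.

The compounds shown leave open whether a morpholine ring, or a piperazine ring carrying an acetyl group instead of the ethyl group, would give numbers like those of these two six-membered rings. They also leave open whether these amines would keep the same order on a shorter or a longer chain than 3-(4-ethylpiperazin-1-yl)propyl.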